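Replacing the triazolylamino group of compound 1 with a fused-ring heterocycle

This account rests on a few compounds, and the source may have more. Where it says the series, first, only, none or still open, it means among the compounds named here.

Measured compounds:
Compound 1 `CC(C)C(Nc1nnc[nH]1)c1ccc(-c2ccc3cccc(F)c3c2)[nH]c1=O` gives 2.42 h in an ADME assay on microsomes from liver (Mus musculus) for metabolic stability; on this read-out lower numbers stand for a shorter-lived compound and higher numbers for a longer-lived compound.
Compound 2 `CC(C)C(c1ncco1)c1ccc(-c2ccc3cccc(F)c3c2)[nH]c1=O` gives 0.08 h in this assay.
Compound 3 `CC(C)C(c1cnc(N)s1)c1ccc(-c2ccc3cccc(F)c3c2)[nH]c1=O` gives 0.08 h in this assay.

Compound 1 stands highest of the three numbers in this assay; its nearest neighbour is compound 2, and compound 3 lies equally far away. Compound 4 `CC(C)C(c1noc(=O)[nH]1)c1ccc(-c2ccc3cccc(F)c3c2)[nH]c1=O` is not yet measured. It differs from compound 1 in one place: a group of 6 heavy atoms (2 carbon, 2 nitrogen, 2 oxygen; one five-membered aromatic ring with 3 hetero atoms) in place of a group of 6 heavy atoms (2 carbon, 4 nitrogen; one five-membered aromatic ring with 3 hetero atoms), on a saturated chain carbon bound to an aromatic carbon and a saturated chain carbon.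

For the measured compounds named here, two measured steps bear on this change, since each also removes the (4H-1,2,4-triazol-3-yl)amino group from the saturated chain carbon and puts a five-membered aromatic ring directly in its place. Both were large: a 30-fold lower number from compound 1 to compound 2 (1.48 log units; beyond the scatter) and a 30-fold lower number from compound 1 to compound 3 (1.48 log units; beyond the scatter). Between compounds 2 and 3 there was no change at the digits printed, so the identity of the entering ring mattered little in those two cases. A step of similar size and direction is therefore expected here, estimated as a 16-fold lower number from compound 1 to compound 4 (1.21 log units; beyond the scatter). Compound 4 is accordingly expected to give about 0.15 h in this assay, with a likely range from 0.05 h to 0.8 h.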

Compound 4, half-life: > 3 h
Compound 4 ended at the assay's limit; the forecaster's own chance of this, stated with the estimate: 5%; middle value at least 20-fold (1.30 log units) from the limit.
By their numbers in this assay, from the lowest: compounds 2 and 3 (each within the scatter of the next); then compound 1. At a limit, above all of these: compound 4.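

In this assay compound 4 stands at a limit and not at a number: the limit of > 3 h in this assay, at which 1 of the 4 values shown sits.

A five-membered aromatic ring set directly on the saturated chain carbon therefore need not give the short half-lives of compounds 2 and 3, as an at least 37-fold higher number from compound 2 to compound 4 (1.57 log units; beyond the scatter) and an at least 37-fold higher number from compound 3 to compound 4 (1.57 log units; beyond the scatter) show, so the identity of the entering ring does matter at this position, which those two compounds alone did not reveal. Against the amino-linked triazole only a floor can be read, an at least 1.2-fold higher number from compound 1 to compound 4 (0.09 log units; that floor lies within the scatter), so the change keeps the long half-life but sets no order between these two compounds.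

From the compounds shown here alone, how far compound 4 lies past its limit stays open, and with it any comparison with compound 1. Also open, going by these compounds, is whether a carboxylic acid on the same saturated chain carbon would follow compound 4 or compounds 2 and 3.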